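This account rests on a few compounds, and the source may have more. Where it says the series, first, only, none or still open, it means among the compounds named here.

Measured compounds in a functional assay on MCF7 cells (Homo sapiens) for antiproliferative activity, read by MTT assay, with a stated time of 72 h; on this read-out lower numbers stand for stronger inhibition and higher numbers for weaker inhibition:
- compound 1 `Cc1cc(S(=O)(=O)/N=C(\N)N/N=C/C#Cc2ccccc2)c(SCc2ccccc2)cc1Cl` gives 24000 nM
- compound 2 `Cc1cc(S(=O)(=O)/N=C(\N)N/N=C/C#Cc2ccccc2)c(SCc2ccccc2C(F)(F)F)cc1Cl` gives 14000 nM
- compound 3 `C/C(C#Cc1ccccc1)=N\N/C(N)=N/S(=O)(=O)c1cc(C)c(Cl)cc1SCc1ccccc1C(F)(F)F` gives 19000 nM

All three numbers lie close together. Compound 3 stands at the second highest of the three, nearest compound 1 and furthest from compound 2, with both gaps within the scatter. Within the data shown here, the only change at the benzylic position bound to sulfur, a 1.7-fold lower number from compound 1 to compound 2 (0.23 log units; within the scatter), stayed within the scatter, and so did the change on the amine nitrogen, a 1.4-fold higher number from compound 2 to compound 3 (0.13 log units; within the scatter).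

Compound 4 `C/C(C#Cc1ccccc1)=N\N/C(N)=N/S(=O)(=O)c1cc(C)c(Cl)cc1SCc1cccc2ccccc12` differs from compound 3 by naphthalen-1-yl in place of 2-(trifluoromethyl)phenyl on a saturated chain carbon bound to a sulfur. Among the measured compounds shown here, the step from compound 1 to compound 2 is the one measured change at this place, and it did not move the number beyond the scatter; nothing measured here separates a second six-membered ring from a trifluoromethyl at that carbon. Compound 4 is therefore expected to give about 20000 nM, with an estimated range from 8000 nM to 50000 nM. The expected step is a 1.1-fold higher number from compound 3 to compound 4 (0.02 log units; within the scatter), a change not beyond the scatter.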

Compound 4, half-maximal inhibitory concentration: 210000 nM
Estimate against measurement, compound 4: 11-fold (1.02 log units) below; the whole stated range lies below it.
By their numbers in this assay, from the lowest: compounds 2, 3 and 1 (each within the scatter of the next); then compound 4.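

In this assay, among these compounds, the saturated chain carbon bound to a sulfur proves sensitive to the group it carries: naphthalen-1-yl in place of 2-(trifluoromethyl)phenyl gives an 11-fold higher number from compound 3 to compound 4 (1.04 log units; beyond the scatter) and is the only step here beyond the scatter. The earlier change at this place, a 1.7-fold lower number from compound 1 to compound 2 (0.23 log units; within the scatter) with trifluoromethyl in place of hydrogen, stayed within the scatter, so this place does not accept every change alike, and the present one moves the number although the leaving and entering groups have equal heavy-atom counts. Nothing shown bears on the reason for the rise.

The compounds shown leave open whether the second six-membered aromatic ring alone carries the change. They also leave open how a pyridine ring or a methoxy-bearing phenyl at this carbon would read.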